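This account rests on a few compounds, and the source may have more. Where it says the series, first, only, none or still open, it means among the compounds named here.

Compound 2 `COc1cc(-c2ccnc3cc(-c4ccc(C(C)(C)C)cc4)nn23)cc(OC)c1OC` carries the shared core with a 4-(tert-butyl)phenyl group and a trimethoxyphenyl group. In a functional assay on HeLa cells (Homo sapiens) for inhibition, read by CCK-8 assay, with a stated time of 48 h (a higher number here means a weaker inhibitor, a lower number a stronger inhibitor), compound 2 gives > 10000 nM, which is a limit of the assay and not a number. Compound 1 `COc1cc(-c2ccnc3c(-c4ccc(C)cc4)cnn23)cc(OC)c1OC` in this assay gives > 10000 nM, likewise a limit. Compound 3 `COc1cc(-c2cc3nccc(-c4c[nH]c5ccccc45)n3n2)cc(OC)c1OC` in this assay gives > 10000 nM, again a limit. For the measured compounds named here, all three measured compounds thus sit at the limit of > 10000 nM in this assay, at which 3 of the 3 values shown sit, so compound 2 stands at the limit together with the others, and no step between measured compounds can be sized or ordered.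

Compound 4 `COc1cc(-c2ccnc3cc(-c4ccc(N(C)C)cc4)nn23)cc(OC)c1OC` differs from compound 2 by dimethylamino in place of tert-butyl on an aromatic carbon. Going by the values given here, no measured pair shows how a change of this kind moves this assay, so its direction is unknown from these data. The expectation for compound 4 is a step from compound 2 of a number no higher from compound 2 to compound 4 (the limit leaves the size open), that is nothing beyond the scatter, with the most likely outcome again a limit. Compound 4 is estimated at 10000 nM in this assay, with a range from 2000 nM to 30000 nM.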

Compound 4, half-maximal inhibitory concentration: 378 nM
The estimate for compound 4 lay 26-fold (1.42 log units) above the measured number; measured number outside the range, below it.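

In this assay, for the compounds shown here, dimethylamino in place of tert-butyl on an aromatic carbon gives an at least 26-fold lower number from compound 2 to compound 4 (1.42 log units; beyond the scatter), the first step that can be sized at all. The group at this position can therefore move a compound of this series off the limit, with the trimethoxyphenyl group and the shared core unchanged. Compound 4 is the only compound shown that gives a number and not a limit: the limit of > 10000 nM in this assay, at which 3 of the 4 values shown sit.

Only these two groups are shown at this position, so it remains open whether the step follows from the entry of dimethylamino or from the departure of tert-butyl. On these data alone, a primary amine, a methoxy group or a morpholine on the same aromatic carbon would help separate the two readings, and the full size of the step stays open with compound 2 at a limit.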